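The source may hold more compounds than are shown below. What is called first, only, known or untested is meant among the compounds shown, and "the series" means these compounds.

Working notes on the series. The shared core of compound 1 `COc1cc(-c2cc(/C=C/C(=O)c3ccc(N)cc3)[nH]n2)cc(OC)c1OC` is kept throughout. Going by the values given here, in a functional assay on MDA-MB-231 cells (Homo sapiens) for inhibition, read by sulforhodamine B assay, with a stated time of 48 h (on this read-out lower numbers stand for stronger inhibition of growth and higher numbers for weaker inhibition of growth), compound 1 gives 2060 nM; this stands second highest of the three numbers so far, with compound 2 `COc1ccc(-c2cc(/C=C/C(=O)c3ccc(N)cc3)[nH]n2)cc1` nearest at 2140 nM and compound 3 `COc1ccc(C(=O)/C=C/c2cc(-c3cc(OC)c(OC)c(OC)c3)n[nH]2)cc1` furthest at 1880 nM, both gaps within the scatter, so no order among the three can be read from these values.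

The step to compound 4 `COc1ccc(C(=O)/C=C/c2cc(-c3cc(OC)c(OC)c(OC)c3)n[nH]2)cc1OC` is 3,4-dimethoxyphenyl in place of 4-aminophenyl on a carbonyl carbon. Among the compounds with values here, the only measured step that bears on it is a 1.1-fold lower number from compound 1 to compound 3 (0.04 log units; within the scatter), where an amino-to-methoxy exchange on the aromatic carbon left the number effectively unchanged. Within the data shown here, the present change again replaces the amino group with methoxy and adds a second methoxy on the same ring; no measured pair speaks to that second methoxy. Among the measured compounds shown here, with the one relevant step flat, no movement beyond the scatter is expected, and compound 4 is estimated at 2000 nM (range 900 nM to 4500 nM). The step of a 1.0-fold lower number from compound 1 to compound 4 (0.01 log units; within the scatter) is thus expected to be small.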

Compound 4, concentration for 50% growth inhibition: 1480 nM
Beside the measured number, compound 4's estimate is 1.4-fold (0.13 log units) above it; low and high end bracket the measured number.
By their numbers in this assay, from the lowest: compounds 4, 3, 1 and 2 (each within the scatter of the next).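

In this assay, the change at the carbonyl carbon gives a 1.4-fold lower number from compound 1 to compound 4 (0.14 log units; within the scatter) and so shows that this position accepts 3,4-dimethoxyphenyl in place of 4-aminophenyl without a movement that can be read. Going by these compounds alone, the second methoxy, which no earlier pair addressed, gives a 1.3-fold lower number from compound 3 to compound 4 (0.10 log units; within the scatter) and likewise leaves the number within the scatter. No measurement is available to explain these values or the flatness of the two steps.

On these data alone, what remains open is whether any replacement on this ring separates from the scatter, for example a carboxylic acid, a dimethylamino group or a longer alkoxy chain in place of methoxy. Also open, as far as these compounds go, is whether replacing the whole aromatic ring on the carbonyl carbon with a saturated ring such as cyclohexyl would move the number.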